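Amide substituent change in the bromo series

The source may report more compounds than this note shows. Statements on the series, on what has been measured and on what is new or still open speak of the compounds shown alone.

Compound 1 `N[C@H]1CC[C@H](Nc2c(C(=O)NCc3ccc(F)cc3)nc(N3CCCCC3)c3cccnc23)CC1` is tested in a functional assay on SK-BR-3 cells (Homo sapiens) for cytotoxicity, read by MTT assay, with a stated time of 72 h; a lower number here means a stronger inhibitor, a higher number a weaker inhibitor. Compound 1 gives only a limit, > 10000 nM, and not a number; this is the limit of > 10000 nM in this assay, at which 1 of the 3 values shown sits. Compound 3 `CNCCCNc1c(C(=O)NCc2ccc(F)cc2)nc(Br)c2cccnc12` gives 1000 nM in this assay. Compound 2 `N[C@H]1CC[C@H](Nc2c(C(=O)NCc3cccc(C(F)(F)F)c3)nc(Br)c3cccnc23)CC1` is recorded as "not determined" (no result reported) in this assay, so no number marks where it stands against compound 1 or compound 3. Compound 4 `N[C@H]1CC[C@H](Nc2c(C(=O)NC3CCCCC3)nc(Br)c3cccnc23)CC1` is still to be measured; it differs from compound 2 by cyclohexyl in place of 3-(trifluoromethyl)benzyl on an amide-type nitrogen. For the measured compounds named here, no measured pair differs in one place, so the size of the step from compound 2 to compound 4 cannot be read from the data, and no direction beyond the scatter is expected. Compound 4 is expected to give about 3000 nM in this assay, within 800 nM to 15000 nM.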

Compound 4, half-maximal inhibitory concentration: 4200 nM
The estimate for compound 4 lay 1.4-fold (0.15 log units) below the measured number, and the stated range covers the measured number.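

In this assay, for the compounds shown here, compound 4 gives 4200 nM, but compound 2 has no number, so no step between compound 2 and compound 4 can be read. As far as these compounds go, the effect of cyclohexyl in place of 3-(trifluoromethyl)benzyl on the amide-type nitrogen stays open.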